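A few compounds are considered here, and "the series" means these few. Any claim that something is new, unique, unknown or untested is made for them only; others in the source may bear on it.

Compound 1 `COc1ccc(CN(CCN(C)C)c2ccc(C(=O)Nc3ccccc3N)cn2)cc1` and compound 2 `COc1ccc(CN(CCN(C)C)c2ccc(C(=O)Nc3cc(Cl)ccc3N)cn2)cc1` share one core and differ only at a single aromatic carbon. In an assay on cells for inhibition of protein deacetylase HDAC6 (Mus musculus), read by fluorescence, with a stated time of 30 min, tested at 100 uM (on this read-out higher numbers stand for more inhibition at the one concentration tested (going by the name of the read-out) and lower numbers for less inhibition), compound 1 gives 11%, and compound 2 gives 7%. The step between them, a number 4 percentage points lower from compound 1 to compound 2 (within the scatter), is within the scatter of repeated measurements, so the two cannot be told apart. Compound 2 stands at the bottom of the two numbers shown, with compound 1 as its only neighbour, but that gap carries no weight.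

Compound 3 `COc1ccc(CN(CCN(C)C)c2ccc(C(=O)Nc3cc(Br)ccc3N)cn2)cc1` is the next compound in this assay. Its change from compound 2 is bromo in place of chloro on an aromatic carbon. Among the measured compounds shown here, the only measured step that touches this part of the molecule is the one from compound 1 to compound 2, in which a chloro entered in place of hydrogen, and that step stayed within the scatter. For the measured compounds named here, no measured pair swaps one halogen for another. The change to bromo is therefore expected to give no step beyond the scatter, an expected step of a number 1 percentage points higher from compound 2 to compound 3 (within the scatter). Compound 3 is estimated at 8%, within a range from 0% to 18%.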

Compound 3, a percentage reported as inhibition, at one concentration (the size of the read-out at that concentration, not a potency): 21%
Beside the measured number, compound 3's estimate is 13 percentage points below it; measured number outside the range, above it.
By their numbers in this assay, from the lowest: compounds 2, 1 and 3 (each within the scatter of the next, the first and the last beyond it).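

Swapping one halogen for another at this carbon, para to an amino group, can move the reading in this assay: the change gives a number 14 percentage points higher from compound 2 to compound 3 (beyond the scatter), the only step among these compounds that clears the usual scatter, so chloro and bromo cannot be treated as interchangeable here. The gain is limited, however, since the comparison with the compound carrying hydrogen at this carbon gives a number 10 percentage points higher from compound 1 to compound 3 (within the scatter), leaving compound 3 and compound 1 indistinguishable, and so bromo is separated only from chloro, not from hydrogen. Nothing measured here bears on why the two halogens part ways.

On these data alone, whether the separation reflects a trend across the halogens remains open, and fluoro or iodo at the same carbon would test that, while a methyl or a nitrile would show how a group other than a halogen reads there. As far as these compounds go, with compound 3 at 21% from a single concentration, it also remains open how these compounds would compare in potency across a full range of concentrations.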